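Swapping the Aryl Group on a Triazole Side Chain

This account rests on a few compounds, and the source may have more. Where it says the series, first, only, none or still open, it means among the compounds named here.

Measured so far in a functional assay on SMMC-7721 cells (Homo sapiens) for cytotoxicity, read by MTT assay, with a stated time of 4 days; a lower number here means a stronger inhibitor, a higher number a weaker inhibitor:
Compound 1 `C=C1C(=O)[C@]23C[C@@]1(O)CC[C@H]2c1ccc(O)c(C)c1[C@@H]3Cn1cc(-c2ccc(C)cc2)nn1`: 920 nM
Compound 2 `C=C1C(=O)[C@]23C[C@@]1(O)CC[C@H]2c1ccc(OS(=O)(=O)c2ccc(C)cc2)c(C)c1[C@@H]3Cn1cc(-c2ccc(C)cc2)nn1`: 4410 nM
Compound 3 `C=C1C[C@]23C[C@@]1(O)CC[C@H]2c1ccc(OS(=O)(=O)c2ccc(C)cc2)c(C)c1[C@@H]3Cn1cc(-c2ccccn2)nn1`: only a limit, > 20000 nM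

Compound 1 gives the lowest of the two numbers that were read as numbers. Its nearest neighbour is compound 2, which differs only by a (4-methylphenyl)sulfonyl in place of hydrogen on an oxygen on an aromatic ring; that change gives a 4.8-fold higher number from compound 1 to compound 2 (0.68 log units; beyond the scatter). For compound 3 the assay reports no number, only (the limit of > 20000 nM in this assay, at which 1 of the 3 values shown sits).

Compound 4 `C=C1C(=O)[C@]23C[C@@]1(O)CC[C@H]2c1ccc(O)c(C)c1[C@@H]3Cn1cc(-c2ccccn2)nn1` is the unmeasured partner of compound 1. The two differ in one place: pyridin-2-yl in place of 4-methylphenyl on an aromatic carbon. Within the data shown here, no measured pair isolates this swap. Compound 3 does carry the pyridin-2-yl group, but it also bears the sulfonyl and lacks the ketone of compound 1 and compound 2, so its limit and the number for compound 2 say only that the combination of these changes weakens the compound, not which change does it. Given that the one measured step from compound 1 was modest and that the swap of aryl groups has no clean precedent, a modest rise in the number is expected for compound 4, as a 2.7-fold higher number from compound 1 to compound 4 (0.43 log units; beyond the scatter), with wide uncertainty. Compound 4 is therefore estimated at 2500 nM, within 800 nM to 10000 nM.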

Compound 4, half-maximal inhibitory concentration: 1270 nM
Compound 4: middle estimate off by 2.0-fold (0.29 log units), on the high side; the range from low to high includes it.
By their numbers in this assay, from the lowest: compounds 1 and 4 (each within the scatter of the next); then compound 2. At a limit, above all of these: compound 3.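

At this aromatic carbon of the five-membered ring, pyridin-2-yl in place of 4-methylphenyl gives a 1.4-fold higher number from compound 1 to compound 4 (0.14 log units; within the scatter) in this assay, so the two compounds cannot be told apart in this assay. Among these compounds, until now, the only change that could be read alone was the one on the oxygen, a 4.8-fold higher number from compound 1 to compound 2 (0.68 log units; beyond the scatter), so this is the first reading at the aryl group, and it shows that this one exchange, from a ring of carbon only with 0 hydrogen-bond acceptors to a ring with 1 hetero atom and 1 hydrogen-bond acceptor, leaves the number within the scatter. Nothing shown here gives a reason for this outcome.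

From the compounds shown here alone, whether the position accepts something other than an aryl ring, such as a carboxylic acid or an aliphatic amine on a longer chain, remains open. Compound 3 also carries pyridin-2-yl but differs from compound 4 in two places, so what that group does in the presence of the sulfonyl also remains open, and the value for compound 3 is only a limit of the assay: the limit of > 20000 nM in this assay, at which 1 of the 4 values shown sits.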